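This account rests on a few compounds, and the source may have more. Where it says the series, first, only, none or still open, it means among the compounds named here.

Working notes on the series. Compound 1 `O=C1COc2ccc(-c3cccc(NS(=O)(=O)c4ccc(F)cc4)c3)cc2N1C1CC1` is the reference point; in a functional assay on HepG2 cells (Homo sapiens) for antiproliferative activity, read by MTT assay, with a stated time of 72 h (a higher number here means a weaker inhibitor, a lower number a stronger inhibitor), compound 1 gives only a limit, > 40000 nM, so where it stands among the measured values is told solely by the limit of > 40000 nM in this assay, at which 1 of the 3 values shown sits. Compound 2 `COc1ncc(-c2ccc3c(c2)N(c2ccc(Cl)cc2)C(=O)CO3)cc1NS(=O)(=O)c1ccc(F)cc1` gives 17900 nM in this assay. Compound 3 `COc1ncc(-c2ccc3c(c2)NC(=O)CO3)cc1NS(=O)(=O)c1ccc(F)cc1` gives 6590 nM. Going by the values given here, the single measured step, a 2.7-fold lower number from compound 2 to compound 3 (0.43 log units; beyond the scatter), runs from an aryl group on the ring nitrogen to hydrogen. Compound 4 `Cc1ccc(N2C(=O)COc3ccc(-c4cccc(NS(=O)(=O)c5ccc(F)cc5)c4)cc32)cc1` differs from compound 1 by 4-methylphenyl in place of cyclopropyl on an amide-type nitrogen in a ring. Among the compounds with values here, no measured pair sets cyclopropyl against 4-methylphenyl at this position; the step from compound 2 to compound 3 bears on it only loosely, and compound 1 already sits at the limit. The expected step is a number no higher from compound 1 to compound 4 (the limit leaves the size open), with a number within the measurable range considered unlikely. Compound 4 is therefore estimated at 40000 nM, between 15000 nM and 90000 nM.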

Compound 4, half-maximal inhibitory concentration: > 40000 nM
Compound 4: only a limit was reported (the forecaster's own chance of this, stated with the estimate: 60%); the middle value sits exactly at the limit.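

Compound 1 and compound 4 both give only a limit in this assay, and the step between them cannot be read: the limit of > 40000 nM in this assay, at which 2 of the 4 values shown sit. The compounds shown leave open how cyclopropyl and 4-methylphenyl on this amide-type nitrogen compare.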